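The compounds below may be only part of what the source reports. "The series", "measured", "known", "first", "only" and "open" are said of these compounds alone.

In an ADME assay on HCT-116 cells (Homo sapiens) for cytotoxicity, read by CellTiter-Glo, with a stated time of 72 h (on this read-out lower numbers stand for stronger inhibition and higher numbers for weaker inhibition), compound 2 `CC1CCN(C2CCN(S(=O)(=O)c3cncc(Br)c3)CC2)CC1` stands at > 10000 nM, which is a limit and not a number. Compound 1 `CC1CCN(C2CCN(S(=O)(=O)c3cccc(Cl)c3)CC2)CC1` gives > 5000 nM, also a limit. Going by the values given here, the only measured step, a step that the two limits leave unreadable from compound 1 to compound 2, therefore gives no usable size. Compound 3 `CC1CCN(C2CCN(S(=O)(=O)c3ccc(Cl)c(Cl)c3)CC2)CC1` brings 3,4-dichlorophenyl in place of 5-bromopyridin-3-yl on a sulfonyl sulfur. The nearest guide is compound 1, which carries 3-chlorophenyl and also ended at a limit, > 5000 nM. Only a small step toward stronger inhibition in this assay is expected, estimated as an at least 1.2-fold lower number from compound 2 to compound 3 (0.09 log units; that floor lies within the scatter). Compound 3 is expected at 8000 nM, within an estimated range of 3000 nM to 20000 nM.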

Compound 3, half-maximal inhibitory concentration: > 5000 nM
Compound 3: a limit, no number; the forecaster's own chance of this, stated with the estimate: 75%; the middle value does not contradict the limit.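

In this assay compound 3 gives > 5000 nM, a limit and not a number, so its steps from compound 1 and from compound 2 cannot be read. The compounds shown leave open what number any of the three would reach, and whether their sulfonyl substituents differ at all in this read-out.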